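A few compounds are considered here, and "the series" means these few. Any claim that something is new, unique, unknown or untested is made for them only; others in the source may bear on it.

In an ADME assay on microsomes from liver (Rattus norvegicus) for metabolic stability, with a stated time of 10 min, tested at 0.5 uM (a higher number here means that more of the compound is left, a lower number that less of the compound is left), compound 1 `Cc1noc(C)c1[C@@H]1C[C@@](C)(c2ccc(F)cc2F)N=C(N)S1` gives 78% and stands highest of the three measured numbers. Compound 3 `Cc1onc(-c2ccc(F)cc2)c1[C@@H]1C[C@@](C)(c2ccc(F)cc2F)N=C(N)S1` gives 35% and compound 2 `Cc1onc(-c2ccccc2)c1[C@@H]1C[C@@](C)(c2ccc(F)cc2F)N=C(N)S1` gives 13% in the same test. Within the data shown here, compound 4 `Cc1noc(C(F)F)c1[C@@H]1C[C@@](C)(c2ccc(F)cc2F)N=C(N)S1` awaits measurement, and difluoromethyl in place of methyl on an aromatic carbon is its only difference from compound 1. Two large steps offer a loose guide: a number 65 percentage points lower from compound 1 to compound 2 (beyond the scatter) and a number 43 percentage points lower from compound 1 to compound 3 (beyond the scatter) when phenyl and 4-fluorophenyl replace a different methyl. A modest step, a number 22 percentage points higher from compound 2 to compound 3 (beyond the scatter) when fluoro replaces hydrogen, applies only to those ring groups. Difluoromethyl brings no ring, so these large drops need not carry over. In this assay the expected change is a number 4 percentage points lower from compound 1 to compound 4 (within the scatter) and probably stays within the scatter. For compound 4 the estimate is 74% with an expected range from 55% to 90% in this test.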

Compound 4, percent of the compound remaining: 67%
The estimate for compound 4 lay 7 percentage points above the measured number; measured number inside the range.
By their numbers in this assay, from the lowest: compound 2; then compound 3; then compound 4; then compound 1.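

Replacing the methyl next to the ring oxygen with difluoromethyl gives, in this assay, a number 11 percentage points lower from compound 1 to compound 4 (beyond the scatter). This is the first change shown at this position, as compound 2 and compound 3 differ from compound 1 at the other methyl, and it shows that a group without a ring can be placed here at a modest cost. Nothing shown explains why the number falls.

As far as these compounds go, how trifluoromethyl, ethyl or an amine would compare at this position remains open. So does the effect of difluoromethyl on the ring atom that bears the other methyl.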